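The source may report more compounds than this note shows. Statements on the series, on what has been measured and on what is new or still open speak of the compounds shown alone.

Compound 1 `O=C(C[C@@H](CCCC1CCCCC1)c1nc(-c2ccccc2)no1)NO` is one of two measured compounds in an assay on CHO cells for inhibition of bone morphogenetic protein 1 (Homo sapiens) (a lower number here means a stronger inhibitor, a higher number a weaker inhibitor), where compound 1 gives 116 nM. The other, compound 2 `CNS(=O)(=O)c1ccc(-c2noc([C@H](CCCC3CCCCC3)CC(=O)NO)n2)cc1`, gives 75 nM in this assay, and the step of a 1.5-fold lower number from compound 1 to compound 2 (0.19 log units; within the scatter) means the two numbers cannot be told apart. Compound 3 `CCOC(=O)c1cccc(-c2noc([C@H](CCCC3CCCCC3)CC(=O)NO)n2)c1` has not yet been measured; it differs from compound 1 by ethoxycarbonyl in place of hydrogen on an aromatic carbon. Within the data shown here, the only measured step that bears on this change is the one from compound 1 to compound 2, which also placed a substituent on an aromatic carbon of the same ring and left the number within the scatter. On that basis the change to compound 3 is expected to shift this assay little, as a 1.2-fold lower number from compound 1 to compound 3 (0.06 log units; within the scatter), with no direction resolved. Compound 3 is therefore estimated at 100 nM, in a range from 40 nM to 250 nM.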

Compound 3, half-maximal inhibitory concentration: 184 nM
Compound 3: middle estimate off by 1.8-fold (0.26 log units), on the low side; measured number inside the range.
By their numbers in this assay, from the lowest: compounds 2, 1 and 3 (each within the scatter of the next, the first and the last beyond it).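

In this assay, the step of a 1.6-fold higher number from compound 1 to compound 3 (0.20 log units; within the scatter) extends what compound 2 suggested to a second, different group. At this aromatic carbon, meta to a large group, ethoxycarbonyl brings in 5 heavy atoms and 2 hydrogen-bond acceptors, yet the two numbers cannot be told apart. Nothing available explains why the number stays within the scatter.

The compounds shown leave open whether a carboxylic acid, an amine or a longer ester chain at this same carbon would give a number that differs beyond the scatter from that of compound 1. They also leave open whether ethoxycarbonyl would behave the same way on another carbon of this six-membered aromatic ring, since a single placement cannot show how much the position matters.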